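Widening the aryl group on the ring nitrogen: compound 3

This account rests on a few compounds, and the source may have more. Where it says the series, first, only, none or still open, it means among the compounds named here.

Of the compounds shown here, two have been measured so far. Compound 1 `CC(C)[C@@H]1CC[C@@H](C)C[C@@]12N(C)C(=O)[C@@H]1[C@H]3C(=O)N(c4ccc(Cl)cc4)C(=O)[C@H]3ON12` and compound 2 `Cc1cccc(N2C(=O)[C@H]3[C@H](ON4[C@@H]3C(=O)N(C)[C@@]43C[C@H](C)CC[C@H]3C(C)C)C2=O)c1` share one core and differ only in the aromatic group attached to an amide-type nitrogen in a ring. In a functional assay, read by spectrophotometry, with a stated time of 2 h, tested at 2 mg/mL (a lower number here means a weaker effect, a higher number a stronger effect of the compound at the concentration tested), compound 1 gives 49.4%. In this assay, among the measured compounds shown here, compound 2 gives 35.3%, the lowest of the two numbers; the only step recorded, a number 14.1 percentage points lower from compound 1 to compound 2 (beyond the scatter), lies beyond the scatter.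

Compound 3 `CC(C)[C@@H]1CC[C@@H](C)C[C@@]12N(C)C(=O)[C@@H]1[C@H]3C(=O)N(c4ccc5ccccc5c4)C(=O)[C@H]3ON12` is not yet measured. It differs from compound 2 by naphthalen-2-yl in place of 3-methylphenyl on an amide-type nitrogen in a ring. For the measured compounds named here, no measured step involves naphthalen-2-yl, so the single known step, a number 14.1 percentage points lower from compound 1 to compound 2 (beyond the scatter), bears on this change only loosely: it shows that swapping the group at this position can move the read-out by a modest amount in either direction, but it says nothing about a larger two-ring group. A change of modest size, more likely upward than downward, is therefore expected, though a step within the scatter is also plausible.

Compound 3 is estimated to give 42% in this assay, within a range of 22% to 62%, which would mean an expected step of a number 6.7 percentage points higher from compound 2 to compound 3 (within the scatter).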

Compound 3, a percentage reported as activity, at one concentration (the size of the read-out at that concentration, not a potency): 43.6%
For compound 3 the middle estimate is 1.6 percentage points below the measured one; low and high end bracket the measured number.
By their numbers in this assay, from the lowest: compounds 2, 3 and 1 (each within the scatter of the next, the first and the last beyond it).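

In this assay, replacing 3-methylphenyl with the larger, two-ring naphthalen-2-yl on an amide-type nitrogen in a ring gives a number 8.3 percentage points higher from compound 2 to compound 3 (within the scatter), and replacing 4-chlorophenyl with it gives a number 5.8 percentage points lower from compound 1 to compound 3 (within the scatter). This position therefore accepts an aryl group of 10 heavy atoms without a clear loss of the read-out, and compound 3 cannot be told apart from either neighbour, even though those two compounds are separated by a number 14.1 percentage points lower from compound 1 to compound 2 (beyond the scatter). Nothing available explains why these aryl groups give the numbers they do.

Going by these compounds, all three groups at this position are carbon-based aromatic rings, with or without a small substituent, so it remains open how the read-out would respond to a ring containing nitrogen, such as pyridinyl, to a phenyl ring bearing a carboxylic acid or an amine, or to a non-aromatic group such as cyclohexyl or a plain butyl chain. On these data alone, each number also comes from a single concentration, so it remains open whether the compounds would differ in potency across a range of concentrations.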